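Sulfonyl versus carbonyl on the ring nitrogen of the core

This account rests on a few compounds, and the source may have more. Where it says the series, first, only, none or still open, it means among the compounds named here.

Measured so far in a functional assay on NCI-H1975 cells (Homo sapiens) for inhibition, read by sulforhodamine B assay, tested at 10 uM; on this read-out higher numbers stand for more inhibition at the one concentration tested (going by the name of the read-out) and lower numbers for less inhibition:
- compound 1 `CN(C)c1ccc(C2CC(c3ccc(-n4ccnc4)cc3)=NN2)cc1` gives 0.1%
- compound 2 `CN(C)c1ccc(C2CC(c3ccc(-n4ccnc4)cc3)=NN2C(=O)c2cc(Cl)cc(Cl)c2)cc1` gives 58.7%
- compound 3 `CN(C)c1ccc(C2CC(c3ccc(-n4ccnc4)cc3)=NN2S(=O)(=O)c2ccc(C#N)cc2)cc1` gives 0.7%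

Compound 3 stands second of the three, within the scatter of compound 1 and far under compound 2. The step of a number 0.6 percentage points higher from compound 1 to compound 3 (within the scatter) shows that adding the (4-cyanophenyl)sulfonyl group to the ring nitrogen changes nothing beyond the scatter, whereas a number 58.6 percentage points higher from compound 1 to compound 2 (beyond the scatter) shows a large gain for the (3,5-dichlorophenyl)carbonyl group, and a number 58 percentage points lower from compound 2 to compound 3 (beyond the scatter) confirms the large gap between the two substituents.

Compound 4 `CN(C)c1ccc(C2CC(c3ccc(-n4ccnc4)cc3)=NN2S(=O)(=O)c2ccc([N+](=O)[O-])cc2)cc1` keeps the sulfonyl arrangement of compound 3 and differs only on the outer ring: nitro in place of cyano on an aromatic carbon. Within the data shown here, no measured step touches this position, so the expectation rests on the sulfonyl compounds alone. Because compound 3 gives 0.7% in this assay, the nitro analogue is expected to stay at the low end; the estimated step of a number 1.3 percentage points higher from compound 3 to compound 4 (within the scatter) is expected to remain within the scatter. Compound 4 is therefore estimated at 2%, in a range from 0% to 14%.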

Compound 4, a percentage reported as inhibition, at one concentration (the size of the read-out at that concentration, not a potency): 53%
Compound 4: middle estimate off by 51 percentage points, on the low side; the whole stated range lies below it.
By their numbers in this assay, from the lowest: compounds 1 and 3 (each within the scatter of the next); then compounds 4 and 2 (each within the scatter of the next).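

The sulfonyl arrangement does not by itself go with a low number in this assay: on the outer ring, nitro in place of cyano on an aromatic carbon gives a number 52.3 percentage points higher from compound 3 to compound 4 (beyond the scatter) and so makes this position decisive for the sulfonyl compounds. The (4-nitrophenyl)sulfonyl group also separates clearly from the hydrogen on the ring nitrogen, with a number 52.9 percentage points higher from compound 1 to compound 4 (beyond the scatter) as the step, while the swap to it from (3,5-dichlorophenyl)carbonyl gives only a number 5.7 percentage points lower from compound 2 to compound 4 (within the scatter) as a step, so the earlier sulfonyl-carbonyl gap does not hold for every sulfonyl group. No measured evidence on hand accounts for the size of the nitro-cyano step.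

Still open, as far as these compounds go, is how an amine or a carboxylic acid on the same aromatic carbon of the (phenyl)sulfonyl group would read out. The compounds shown also leave open whether nitro in place of cyano gives a step of this size with a carbonyl on the ring nitrogen.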